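A few compounds are considered here, and "the series" means these few. Any claim that something is new, unique, unknown or untested is made for them only; others in the source may bear on it.

Measured so far in a functional assay on NCI-H460 cells (Homo sapiens) for antiproliferative activity, read by MTT assay, with a stated time of 72 h; a lower number here means a stronger inhibitor, a higher number a weaker inhibitor:
- compound 1 `O=C(Nc1ccc(Oc2ccnc3[nH]ccc23)c(F)c1)c1cc2cccnc2n(-c2ccccc2)c1=O` gives 180 nM
- compound 2 `Cn1ccc2c(Oc3ccc(NC(=O)c4cc5cccnc5n(-c5ccccc5)c4=O)cc3)ccnc21` gives 560 nM
- compound 3 `Cn1ccc2c(Oc3ccc(NC(=O)c4cc5cccnc5n(-c5ccc(F)cc5)c4=O)cc3)ccnc21` gives 260 nM

Compound 2 has the highest number of the three in this assay; its nearest neighbour is compound 3, and compound 1 is the furthest from it. Compound 4 `Cn1ccc2c(Oc3ccc(NC(=O)c4cc5cccnc5n(-c5ccccc5)c4=O)cc3F)ccnc21` differs from compound 2 by fluoro in place of hydrogen on an aromatic carbon. Among the measured compounds shown here, no measured pair shows exactly this change. For the measured compounds named here, compound 1 carries a fluoro at the same place but also differs from compound 2 elsewhere, so the two values show only that compound 1 gives the lower number. Going by the values given here, the only single-point step with a fluoro, elsewhere on the molecule, is a 2.2-fold lower number from compound 2 to compound 3 (0.33 log units; beyond the scatter). On that basis a modest downward step in this assay is expected for compound 4, with the estimated size of the step being a 1.9-fold lower number from compound 2 to compound 4 (0.27 log units; within the scatter). Compound 4 is therefore estimated at 300 nM, within a range of 120 nM to 750 nM.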

Compound 4, half-maximal inhibitory concentration: 550 nM
Compound 4: the middle estimate sits 1.8-fold (0.26 log units) below what was measured; the range from low to high includes it.
By their numbers in this assay, from the lowest: compounds 1 and 3 (each within the scatter of the next); then compounds 4 and 2 (each within the scatter of the next).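

In this assay, fluoro in place of hydrogen at this place, ortho to a large group and meta to a large group, gives a 1.0-fold lower number from compound 2 to compound 4 (0.01 log units; within the scatter); the fluoro elsewhere on the molecule gave a 2.2-fold lower number from compound 2 to compound 3 (0.33 log units; beyond the scatter), so the earlier step does not carry over to this position. Among the compounds shown here, with the fluoro held constant, methyl in place of hydrogen on the aromatic nitrogen gives a 3.1-fold higher number from compound 1 to compound 4 (0.49 log units; beyond the scatter), the first single-change reading of that methyl. Nothing at hand explains either step.

The compounds shown leave open whether a chloro, a methoxy or an amine at this place would move the number. They also leave open what fluoro does here when the aromatic nitrogen carries hydrogen rather than methyl.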